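Semicarbazone replacing dithiocarbazate on a shared naphthopyran core

A few compounds are considered here, and "the series" means these few. Any claim that something is new, unique, unknown or untested is made for them only; others in the source may bear on it.

Of the compounds shown here, three built on the same core have been measured in a functional assay on MCF7 cells (Homo sapiens) for antiproliferative activity, read by MTT assay, with a stated time of 96 h; on this read-out higher numbers stand for weaker inhibition and lower numbers for stronger inhibition. Compound 1, `CSC(=S)N/N=C1\CC2(CCCCC2)Oc2c1ccc1ccccc21`, gives 5100 nM and stands at the lowest number of the three. Compound 2, `S=C(CN1CCCCC1)N/N=C1\CC2(CCCCC2)Oc2c1ccc1ccccc21`, gives 11700 nM, and compound 3, `S=C(N/N=C1\CC2(CCCCC2)Oc2c1ccc1ccccc21)NC1CCCCC1`, gives 15100 nM. The two measured steps away from compound 1 both replace the methylsulfanyl group on the thiocarbonyl carbon with a larger group, and both push the number up: a 2.3-fold higher number from compound 1 to compound 2 (0.36 log units; beyond the scatter) and a 3.0-fold higher number from compound 1 to compound 3 (0.47 log units; beyond the scatter). Between compound 2 and compound 3 the difference is a 1.3-fold higher number from compound 2 to compound 3 (0.11 log units; within the scatter).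

Compound 4, `O=C(N/N=C1\CC2(CCCCC2)Oc2c1ccc1ccccc21)Nc1ccc(Cl)cc1`, has not yet been measured. It differs from compound 1 in this way: a group of 10 heavy atoms (7 carbon, 1 nitrogen, 1 oxygen, 1 chlorine; one six-membered aromatic ring of carbon only) in place of a group of 4 heavy atoms (2 carbon, 2 sulfur; no ring), on an amine nitrogen

Among the compounds with values here, no measured step changes this part of the molecule in the same way, so the two steps from compound 1 only show that enlarging the group beyond the thiohydrazone nitrogen has, so far, weakened inhibition modestly. On that basis compound 4 is expected to fall modestly above compound 1, with a 2.4-fold higher number from compound 1 to compound 4 (0.37 log units; beyond the scatter) as the estimated step, while the range stays wide. The estimate for compound 4 in this assay is 12000 nM, between 4000 nM and 40000 nM.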

Compound 4, half-maximal inhibitory concentration: 15000 nM
Compound 4: middle estimate off by 1.3-fold (0.10 log units), on the low side; low and high end bracket the measured number.
By their numbers in this assay, from the lowest: compound 1; then compounds 2, 4 and 3 (each within the scatter of the next).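

In this assay, putting (4-chlorophenyl)carbamoyl on the amine nitrogen gives a 2.9-fold higher number from compound 1 to compound 4 (0.47 log units; beyond the scatter). This shows that the higher number seen with compounds 2 and 3 also holds for a group with a carbonyl in place of the thiocarbonyl and an aromatic ring in place of a saturated one. Compound 4 sits with both of them, with a 1.0-fold lower number from compound 3 to compound 4 (0.00 log units; within the scatter) and a 1.3-fold higher number from compound 2 to compound 4 (0.11 log units; within the scatter) as the two steps, so these quite different groups cannot be told apart here and only compound 1 stands apart from the rest. No measured evidence on the reason for this result is available.

The change to compound 4 alters the carbonyl and the ring at once, so what the compounds shown leave open is which of the two, if either, accounts for the step from compound 1. A plain phenyl without the chlorine, or a small group such as methylamino or ethylsulfanyl on the same carbon, would help show whether the size of the group or the sulfur of methylsulfanyl sets compound 1 apart.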